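The source may report more compounds than this note shows. Statements on the series, on what has been measured and on what is new or still open speak of the compounds shown alone.

Three compounds have a number in a functional assay on MV4-11 cells (Homo sapiens) for antiproliferative activity, read by CellTiter-Glo, with a stated time of 72 h; on this read-out higher numbers stand for weaker inhibition and lower numbers for stronger inhibition:

Compound 1 `CO[C@@H]1[C@H](N(C)c2ncc(-c3c[nH]c4ccc(Br)cc34)s2)C[C@H]2O[C@]1(C)n1c3ccccc3c3c4c(c5c6ccccc6n2c5c31)C(=O)NC4`: 410 nM
Compound 2 `COc1ccc2[nH]cc(-c3cnc(N(C)[C@@H]4C[C@H]5O[C@@](C)([C@@H]4OC)n4c6ccccc6c6c7c(c8c9ccccc9n5c8c64)C(=O)NC7)s3)c2c1`: 360 nM
Compound 3 `CO[C@@H]1[C@H](N(C)c2ncc(-c3c[nH]c4ccc(Br)cc34)s2)C[C@H]2O[C@]1(C)n1c3ccccc3c3c4c(c5c6cc(Br)ccc6n2c5c31)C(=O)NC4`: 390 nM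

Compound 2 arises from compound 1 by one change, (methoxy in place of bromo on an aromatic carbon), and this change made the step of a 1.1-fold lower number from compound 1 to compound 2 (0.06 log units; within the scatter). Compound 4 `COc1ccc2[nH]cc(-c3cnc(N(C)[C@@H]4C[C@H]5O[C@@](C)([C@@H]4OC)n4c6ccccc6c6c7c(c8c9cc(Br)ccc9n5c8c64)C(=O)NC7)s3)c2c1` is not yet measured; it arises from compound 3 by methoxy in place of bromo on an aromatic carbon. Among the four compounds this change occurs twice, and in both cases the group sits at the same kind of position, so it is the same change made on two cores. The two cores differ by bromo in place of hydrogen on an aromatic carbon, a change that gave the step of a 1.1-fold lower number from compound 1 to compound 3 (0.02 log units; within the scatter). Because the step of a 1.1-fold lower number from compound 1 to compound 2 (0.06 log units; within the scatter) was within the scatter, the same change on the core of compound 3 is expected to stay within the scatter as well, giving an estimated step of a 1.1-fold lower number from compound 3 to compound 4 (0.05 log units; within the scatter) in this assay. On that basis compound 4 is expected to give about 350 nM, with a likely range from 180 nM to 700 nM.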

Compound 4, half-maximal inhibitory concentration: 510 nM
Estimate against measurement, compound 4: 1.5-fold (0.16 log units) below; the measured number falls inside the stated range.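

In this assay, 5-methoxy-1H-indol-3-yl in place of 5-bromo-1H-indol-3-yl gives a 1.3-fold higher number from compound 3 to compound 4 (0.12 log units; within the scatter), and this agrees with the same change on the other core: the same change on two cores in this assay, a 1.1-fold lower number (0.06 log units; within the scatter) from compound 1 to compound 2 and a 1.3-fold higher number (0.12 log units; within the scatter) from compound 3 to compound 4, 1.5-fold (0.17 log units) apart, within the scatter of two such steps. Bromo in place of hydrogen on an aromatic carbon gives a 1.4-fold higher number from compound 2 to compound 4 (0.15 log units; within the scatter), and this also agrees with its earlier counterpart: the same change on two cores in this assay, a 1.1-fold lower number (0.02 log units; within the scatter) from compound 1 to compound 3 and a 1.4-fold higher number (0.15 log units; within the scatter) from compound 2 to compound 4, 1.5-fold (0.17 log units) apart, within the scatter of two such steps. For the compounds shown here, both changes therefore carry from one core to the other without a detectable difference, but every step here is itself within the scatter, so this shows only that neither change moved the number measurably on these cores, not that a change with a larger step would carry across as well.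

From the compounds shown here alone, only bromo and methoxy appear at one of the two places, and only hydrogen and bromo at the other, so the effect of an amine, a carboxylic acid or a longer chain such as ethoxy stays open. Going by these compounds, all four numbers also come from one assay on one cell line, so it remains open whether the same holds in any other test.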